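The source may report more compounds than this note shows. Statements on the series, on what has been measured and on what is new or still open speak of the compounds shown alone.

Compound 1 `O=C(/C(=C\c1ccccc1OCc1ccccc1)Sc1ccc(F)cc1)c1ccc(Cl)cc1`: 1000 nM
Compound 2 `O=C(/C(=C\c1cc(Cl)c(O)c(Cl)c1)S(=O)(=O)Cc1ccc(Br)cc1)c1ccc(Br)cc1`: 25000 nM

Both numbers come from a functional assay on DU-145 cells (Homo sapiens) for inhibition, read by trypan blue exclusion, with a stated time of 96 h; on this read-out higher numbers stand for weaker inhibition of growth and lower numbers for stronger inhibition of growth. Among the compounds with values here, of the two, compound 1 carries the lower number; compound 2 gives 25000 nM, a gap that lies beyond the usual scatter, and no single-point step links the two structures. Compound 3 `O=C(/C(=C\c1ccccc1OCc1ccccc1)Sc1ccc(Br)cc1)c1ccc(Cl)cc1` keeps the core of compound 1 and differs from it in one place: bromo in place of fluoro on an aromatic carbon. Within the data shown here, no measured pair shows this exchange, so the step from compound 1 to compound 3 is expected to be small, within the scatter, with a 1.1-fold lower number from compound 1 to compound 3 (0.05 log units; within the scatter) as its estimated size. Compound 3 is therefore expected to give 900 nM, in a range from 300 nM to 3000 nM.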

Compound 3, concentration for 50% growth inhibition: 10000 nM
Estimate against measurement, compound 3: 11-fold (1.05 log units) below; the measured number lies above the stated range.
By their numbers in this assay, from the lowest: compound 1; then compound 3; then compound 2.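

Bromo in place of fluoro on this aromatic carbon, para to a large group, brings a 10-fold higher number from compound 1 to compound 3 (1.00 log units; beyond the scatter) and clearly weakens growth inhibition. Within the data shown here, this is the first direct sign that this position responds to which halogen it carries, something the unlinked compound 1 and compound 2 could not show. No measurement at hand explains the change.

On these data alone, whether chloro, methoxy or an amine at this position would give a number nearer that of compound 1 or compound 3 remains open. So does whether the same exchange would matter as much on the other aromatic rings.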